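Sulfonyl-group variation: working notes toward compound 4

This account rests on a few compounds, and the source may have more. Where it says the series, first, only, none or still open, it means among the compounds named here.

Measured so far:
Compound 1 `Cc1ccc(S(=O)(=O)Nc2ccc(-c3nc4ccccc4o3)cc2)cc1` in an assay on isolated protein for inhibition of malate dehydrogenase, mitochondrial (Sus scrofa), with stated times of 45 min and 30 min (a lower number here means a stronger inhibitor, a higher number a weaker inhibitor), gives > 63000 nM, which is a limit of the assay and not a number.
Compound 2 `O=S(=O)(Nc1ccc(-c2nc3ccccc3o2)cc1)c1ccc(Cl)s1` in this assay gives > 63000 nM, again a limit.
Compound 3 `O=S(=O)(Nc1ccc(-c2nc3ccccc3o2)cc1)c1cccc(O)c1` in this assay gives > 63000 nM, also a limit.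

Compound 3 therefore stands only at a limit, and the two other values shown are limits as well, because of the limit of > 63000 nM in this assay, at which 3 of the 3 values shown sit. The steps a step that the two limits leave unreadable from compound 1 to compound 2, a step that the two limits leave unreadable from compound 1 to compound 3 and a step that the two limits leave unreadable from compound 2 to compound 3 each exchange the group on the sulfonyl sulfur, yet none of them can be read in size, since both ends of each step sit at the limit.

Compound 4 `CS(=O)(=O)Nc1ccc(-c2nc3ccccc3o2)cc1` is not yet measured. It differs from compound 3 by methyl in place of 3-hydroxyphenyl on a sulfonyl sulfur. Within the data shown here, the steps that bear on this change are the two that end at compound 3, and both are unreadable; they give no sign that any exchange of the group on the sulfonyl sulfur moves the read-out off the limit. No step beyond the scatter is therefore expected in this assay, in either direction. Compound 4 is estimated at 120000 nM, with a range from 40000 nM to 600000 nM. The expected step that the limit leaves unreadable from compound 3 to compound 4 is thus no more than a placeholder around the limit.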

Compound 4, half-maximal inhibitory concentration: > 63000 nM
Compound 4: a limit, no number; the forecaster's own chance of this, stated with the estimate: 85%; the middle value does not contradict the limit.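

Among these compounds, no step from compound 1, compound 2 or compound 3 to compound 4 can be read, as both ends of each sit at a limit: the limit of > 63000 nM in this assay, at which 4 of the 4 values shown sit.

The compounds shown leave open whether any group on the sulfonyl sulfur brings the read-out in this assay off this limit.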